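A benzothiazole in place of a ring group

A few compounds are considered here, and "the series" means these few. Any claim that something is new, unique, unknown or untested is made for them only; others in the source may bear on it.

Of the compounds shown here, three have been measured in an ADME assay on microsomes from liver (Rattus norvegicus) for metabolic stability, read by LC-MS, with a stated time of 10 min, tested at 0.5 uM; on this read-out higher numbers stand for a more stable compound and lower numbers for a less stable compound. Here compound 1 (`c1ccc2c(c1)CN[C@H](CN(CCCN1CCNCC1)[C@H]1CCCc3cccnc31)C2`) gives 88%, compound 2 (`c1cnc2c(c1)CN[C@H](CN(CCCN1CCNCC1)[C@H]1CCCc3cccnc31)C2`) gives 87% and compound 3 (`c1cnc2c(c1)CN[C@@H](CN(CCCN1CCNCC1)[C@H]1CCCc3cccnc31)C2`) gives 79%. Compound 3 therefore stands within the scatter of both others, with gaps of a number 9 percentage points lower from compound 1 to compound 3 (within the scatter) and a number 8 percentage points lower from compound 2 to compound 3 (within the scatter).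

Compound 4 (`c1cnc2c(c1)CCC[C@@H]2N(CCCN1CCNCC1)Cc1nc2ccccc2s1`) differs from compound 3 in one place: a group of 9 heavy atoms (7 carbon, 1 nitrogen, 1 sulfur; one five-membered aromatic ring with 2 hetero atoms, one six-membered aromatic ring of carbon only) in place of a group of 10 heavy atoms (8 carbon, 2 nitrogen; one six-membered non-aromatic ring with 1 hetero atom, one six-membered aromatic ring with 1 hetero atom), on a saturated chain carbon bound to an amine nitrogen. The entering 1,3-benzothiazol-2-yl group sits on a saturated chain carbon bound to an amine nitrogen, and it has 0 hydrogen-bond donors where the group that leaves has 1.

Going by the values given here, three measured steps bear on this change. Exchanging the group at this same place gave a number 1 percentage points lower from compound 1 to compound 2 (within the scatter) and also a number 9 percentage points lower from compound 1 to compound 3 (within the scatter), while altering one stereocentre in that group gave a number 8 percentage points lower from compound 2 to compound 3 (within the scatter). Among the compounds with values here, these exchanges kept a six-membered non-aromatic ring, however, and no measured compound carries a five-membered aromatic ring with 2 hetero atoms, leaving the guide a loose one.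

None of these steps left the scatter, and none beyond it is expected in this assay here, though a slight fall is possible. The estimated step is a number 4 percentage points lower from compound 3 to compound 4 (within the scatter). For compound 4 the expected value is 75%, with an estimated range from 52% to 90%.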

Compound 4, percent of the compound remaining: 21%
Estimate against measurement, compound 4: 54 percentage points above; the whole stated range lies above it.
By their numbers in this assay, from the lowest: compound 4; then compounds 3, 2 and 1 (each within the scatter of the next).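

At this place, on a saturated chain carbon bound to an amine nitrogen, this assay proves highly sensitive to the attached group: bringing in 1,3-benzothiazol-2-yl gives a number 58 percentage points lower from compound 3 to compound 4 (beyond the scatter) and a number 66 percentage points lower from compound 2 to compound 4 (beyond the scatter) and a number 67 percentage points lower from compound 1 to compound 4 (beyond the scatter) in turn. The earlier exchanges all stayed within the scatter, whether the aromatic ring of the leaving group was carbon-only or held a hetero atom and whichever configuration was drawn, so this place looked tolerant, and compound 4 shows that this does not hold for every group. Nothing available here says why the number drops so far.

The change replaces a fused ring group that holds a six-membered non-aromatic ring and a hydrogen-bond donor with one that has neither and also brings in a five-membered aromatic ring with sulfur, so the compounds shown cannot separate these differences. A 1,3-benzoxazol-2-yl group, with oxygen in place of the sulfur, or a 1,2,3,4-tetrahydroisoquinolin-3-yl group compared with a plain benzyl-type phenyl group at the same place, would help show which of these differences goes with the low number.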